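Changing the aryl group on the core of a sulfonamide series

This account rests on a few compounds, and the source may have more. Where it says the series, first, only, none or still open, it means among the compounds named here.

Compound 1, `N#CC1=C(N)N(c2ccc(S(N)(=O)=O)cc2)C2=C(C(=O)CCC2)C1c1ccccc1`, gives 40% in a functional assay on Ehrlich cells (Mus musculus) for antiproliferative activity, read by trypan blue exclusion, with a stated time of 2 h, tested at 100 ug/mL; a lower number here means a weaker effect, a higher number a stronger effect of the compound at the concentration tested.
Compound 2, `N#CC1=C(N)N(c2ccc(S(N)(=O)=O)cc2)C2=C(C(=O)CCC2)C1c1ccc(O)cc1`, gives 100%.
Compound 3, `N#CC1=C(N)N(c2ccc(S(N)(=O)=O)cc2)C2=C(C(=O)CCC2)C1c1ccc(Cl)cc1Cl`, gives 95%.

Compound 2 holds the highest of the three numbers. Compound 3 sits nearest, and the step of a number 5 percentage points lower from compound 2 to compound 3 (within the scatter) lies within the scatter, so the two cannot be ranked against each other. Compound 1 lies furthest away, and the step of a number 60 percentage points higher from compound 1 to compound 2 (beyond the scatter) is large.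

Compound 4, `COc1ccc2ccccc2c1C1C(C#N)=C(N)N(c2ccc(S(N)(=O)=O)cc2)C2=C1C(=O)CCC2`, has not yet been measured. Relative to compound 2 the change is 2-methoxynaphthalen-1-yl in place of 4-hydroxyphenyl on a saturated ring carbon. The measured steps that bear on this concern the same saturated ring carbon. The step of a number 55 percentage points higher from compound 1 to compound 3 (beyond the scatter) shows that a substituted aryl group in place of a bare phenyl raises the number strongly, and the step of a number 5 percentage points lower from compound 2 to compound 3 (within the scatter) shows that exchanging one substituted aryl group for another stays within the scatter. Among the measured compounds shown here, compound 4 keeps a substituted aromatic group on that carbon, but it loses the hydrogen-bond donor of compound 2 and brings in a second aromatic ring, and no measured step covers either of those features. The expectation is therefore a modest decrease, a number 20 percentage points lower from compound 2 to compound 4 (beyond the scatter), with wide uncertainty. Compound 4 is estimated at 80%, within a range from 45% to 100%.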

Compound 4, a percentage reported as activity, at one concentration (the size of the read-out at that concentration, not a potency): 80%
Beside the measured number, compound 4's estimate shows no gap at the digits printed; measured number inside the range.
By their numbers in this assay, from the lowest: compound 1; then compound 4; then compounds 3 and 2 (each within the scatter of the next).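

In this assay, among the compounds shown here, this saturated ring carbon tolerates a much larger aryl group than the earlier compounds showed: 2-methoxynaphthalen-1-yl, with its 2 six-membered aromatic rings and 0 hydrogen-bond donors, still gives a number 40 percentage points higher from compound 1 to compound 4 (beyond the scatter) and so keeps a clear gain over the bare phenyl. The position does, however, separate substituted aryl groups from one another, which the earlier pair of compound 2 and compound 3 could not show. The exchange gives a number 20 percentage points lower from compound 2 to compound 4 (beyond the scatter) and also a number 15 percentage points lower from compound 3 to compound 4 (beyond the scatter) so a substituted aryl group here does not guarantee a number as high as those of compound 2 and compound 3.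

On these data alone, compound 4 differs from compound 2 by the hydroxy group, the methoxy group and the second aromatic ring all at once, so the step cannot be assigned to any one of them, and plain naphthalen-1-yl, 2-hydroxynaphthalen-1-yl, 4-methoxyphenyl, 4-aminophenyl or 4-carboxyphenyl groups at this carbon remain open. The reason for any of these differences also stays open, as nothing measured here speaks to it.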